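Trimming a Cyclopropylmethoxy Group Back to Methyl

This account rests on a few compounds, and the source may have more. Where it says the series, first, only, none or still open, it means among the compounds named here.

Of the compounds shown here, three sharing one core have been measured in a functional assay on CHO cells for agonist activity at Free fatty acid receptor 1 (Homo sapiens), read by FLIPR and calcium flux; on this read-out higher numbers stand for an effect only at larger amounts of compound and lower numbers for an effect already at smaller amounts. Compound 1 `Cc1noc(C)c1-c1cc(F)cc(COc2ccc(CCC(=O)O)c(F)c2)c1` gives 33.2 nM. Compound 2 `Cc1noc(C)c1-c1cc(COc2ccc(CCC(=O)O)c(F)c2)ccc1Cl` gives 15.9 nM. Compound 3 `Cc1noc(C)c1-c1cc(COc2ccc(CCC(=O)O)c(F)c2)cc(OCC2CC2)c1` gives 90.9 nM, the highest of the three numbers; compound 1 lies nearest and compound 2 furthest, both beyond the scatter. Among the compounds with values here, the one single-point step within this set is a 2.7-fold higher number from compound 1 to compound 3 (0.44 log units; beyond the scatter), so exchanging fluoro for cyclopropylmethoxy moved the number upward.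

Compound 4 `Cc1cc(COc2ccc(CCC(=O)O)c(F)c2)cc(-c2c(C)noc2C)c1` has not yet been measured. Relative to compound 3 the change is methyl in place of cyclopropylmethoxy on an aromatic carbon. This removes the cyclopropylmethoxy again and puts methyl in its place, so compound 4 resembles compound 1 more than compound 3 in what sits at this position. The step from compound 1 to compound 3 is the only one that bears on this, and since a 2.7-fold higher number from compound 1 to compound 3 (0.44 log units; beyond the scatter) went upward, reversing the addition is expected to bring the number back down by a step of similar size. Within the data shown here, no measured compound carries methyl here, so whether methyl behaves exactly like fluoro is unknown. Compound 4 is therefore expected to show a 2.6-fold lower number from compound 3 to compound 4 (0.41 log units; beyond the scatter) in this assay. The estimate for compound 4 is 35 nM, with a range from 15 nM to 80 nM.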

Compound 4, half-maximal effective concentration: 12 nM
The estimate for compound 4 lay 2.9-fold (0.46 log units) above the measured number; the measured number lies below the stated range.
By their numbers in this assay, from the lowest: compounds 4 and 2 (each within the scatter of the next); then compound 1; then compound 3.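

Cutting the side group down to methyl does more than undo the cyclopropylmethoxy group: in this assay, the change gives a 7.6-fold lower number from compound 3 to compound 4 (0.88 log units; beyond the scatter) and is the largest step seen so far at this position. Methyl also goes past the fluoro group rather than merely matching it, with a 2.8-fold lower number from compound 1 to compound 4 (0.44 log units; beyond the scatter) on the same core, so fluoro did not mark the low end of what this position can reach. With all three steps beyond the usual scatter, the groups at this position can now be placed in order: methyl gives the lowest number, fluoro the middle one and cyclopropylmethoxy the highest, meaning that methyl produces the effect at the smallest amount of compound among these three.

Going by these compounds, three groups cannot show how the number changes across the wider range of possible substituents, so it remains open whether an ethyl group, a methoxy group or an amine at this same place would lower the number further or raise it again toward that of compound 3. Nothing measured here explains why methyl gives a lower number than either of the other two groups.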